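Aryl amine exchange at the amino substituent of compound 3

The source may report more compounds than this note shows. Statements on the series, on what has been measured and on what is new or still open speak of the compounds shown alone.

Three compounds share one core and differ at the amine carried by it. Compound 1 `CCCCCCCCNc1nc(SCc2ccc(C(F)(F)F)cc2)nc2ccccc12` gives 12600 nM in a functional assay on MGC-803 cells (Homo sapiens) for cytotoxicity, read by MTT assay, with a stated time of 72 h; a higher number here means a weaker inhibitor, a lower number a stronger inhibitor; compound 2 `FC(F)(F)c1ccc(CSc2nc(N3CCCCC3)c3ccccc3n2)cc1` gives 18600 nM; compound 3 `Cc1ccccc1Nc1nc(SCc2ccc(C(F)(F)F)cc2)nc2ccccc12` gives 24400 nM. Compound 3 sits at one end of the three numbers, separated from compound 2 by a 1.3-fold higher number from compound 2 to compound 3 (0.12 log units; within the scatter) and from compound 1 by a 1.9-fold higher number from compound 1 to compound 3 (0.29 log units; within the scatter), both within the scatter, as is a 1.5-fold higher number from compound 1 to compound 2 (0.17 log units; within the scatter). The next compound, compound 4 `FC(F)(F)c1ccc(CSc2nc(Nc3cccc(Cl)c3)c3ccccc3n2)cc1`, carries 3-chlorophenyl in place of 2-methylphenyl on a nitrogen on an aromatic ring. Within the data shown here, the only measured step touching this position, a 1.9-fold higher number from compound 1 to compound 3 (0.29 log units; within the scatter), exchanged a chain for an aromatic ring without moving the number beyond the scatter, and no measured pair swaps one aromatic ring for another on this nitrogen. A step within the scatter, in no clear direction, is therefore expected in this assay; compound 4 is estimated at 22000 nM, with a range of 9000 nM to 55000 nM, which is an expected step of a 1.1-fold lower number from compound 3 to compound 4 (0.04 log units; within the scatter).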

Compound 4, half-maximal inhibitory concentration: 14600 nM
Beside the measured number, compound 4's estimate is 1.5-fold (0.18 log units) above it; measured number inside the range.
By their numbers in this assay, from the lowest: compounds 1, 4, 2 and 3 (each within the scatter of the next).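

In this assay, among these compounds, the first measured exchange of one aromatic ring for another on this nitrogen, 3-chlorophenyl in place of 2-methylphenyl, gives a 1.7-fold lower number from compound 3 to compound 4 (0.22 log units; within the scatter). Among the compounds shown here, the new aryl amine also stays within the scatter of the two other amines: (3-chlorophenyl)amino in place of piperidin-1-yl gives a 1.3-fold lower number from compound 2 to compound 4 (0.11 log units; within the scatter), and 3-chlorophenyl in place of octyl gives a 1.2-fold higher number from compound 1 to compound 4 (0.06 log units; within the scatter), so no step among the four compounds separates them at this position. No supporting data are available to account for these numbers.

Going by these compounds, it remains open whether any group on this nitrogen gives a step beyond the scatter, for example a phenyl ring carrying a carboxylic acid, or a shorter chain such as butyl. On these data alone, the group carrying trifluoromethyl is the same in all four compounds, so the effect of a nitrile in place of trifluoromethyl also remains open.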